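The compounds below may be only part of what the source reports. "The series", "measured", "known", "first", "only" and "open" are said of these compounds alone.

Among the measured compounds shown here, compound 2 `CCN(CC)S(=O)(=O)c1ccc(S(=O)(=O)N2CCC[C@@H](C(=O)N3CC[C@H](OC)C3)C2)cc1` gives 6750 nM in a functional assay on BXPC-3 cells (Homo sapiens) for inhibition, read by MTT assay, with a stated time of 7 days (a higher number here means a weaker inhibitor, a lower number a stronger inhibitor), and stands, among the two numbers measured, within the scatter of compound 1 `CCN(CC)S(=O)(=O)c1ccc(S(=O)(=O)N2CCC[C@@H](C(=O)N3CCC(O)CC3)C2)cc1`, which in this assay gives 4710 nM; the only step between them, a 1.4-fold higher number from compound 1 to compound 2 (0.16 log units; within the scatter), is also an exchange of the amide ring. Compound 3 `CCN(CC)S(=O)(=O)c1ccc(S(=O)(=O)N2CCC[C@@H](C(=O)N3CCC(C(F)F)CC3)C2)cc1` differs from compound 2 by 4-(difluoromethyl)piperidin-1-yl in place of 3-methoxypyrrolidin-1-yl on a carbonyl carbon. For the measured compounds named here, only that one small step bears on this change, so no step beyond the scatter is expected. Compound 3 is therefore estimated at 6000 nM, between 2500 nM and 15000 nM. For compound 3 this expectation means a 1.1-fold lower number from compound 2 to compound 3 (0.05 log units; within the scatter).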

Compound 3, half-maximal inhibitory concentration: 450 nM
Compound 3: the middle estimate sits 13-fold (1.12 log units) above what was measured; the measured number lies below the stated range.
By their numbers in this assay, from the lowest: compound 3; then compounds 1 and 2 (each within the scatter of the next).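

Within this assay the group on this carbonyl carbon proves able to shift the number strongly, which the earlier exchange within the scatter did not show: a 15-fold lower number from compound 2 to compound 3 (1.18 log units; beyond the scatter). The hydroxy and difluoromethyl compounds share the same six-membered ring, and difluoromethyl in place of hydroxy on a saturated ring carbon alone gives a 10-fold lower number from compound 1 to compound 3 (1.02 log units; beyond the scatter). Nothing measured here explains this gain. The compounds shown leave open whether the gain needs difluoromethyl specifically or would also appear with methyl, trifluoromethyl or plain piperidin-1-yl. They also leave open whether difluoromethyl would give it on a pyrrolidin-1-yl ring.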